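The compounds below may be only part of what the source reports. "The series", "measured", "known", "first", "only" and "open" are said of these compounds alone.

Measured so far:
- compound 1, `CCCC#Cc1cc([C@@H]2O[C@H](CO)[C@@H](O)[C@H]2O)n2ncnc(N)c12`: 200 nM
- compound 2, `Nc1ncnn2c([C@@H]3O[C@H](CO)[C@@H](O)[C@H]3O)cc(-c3ccc(Cl)cc3)c12`: 37900 nM

In a functional assay on HL-60 cells (Homo sapiens) for antiproliferative activity, with a stated time of 72 h (on this read-out higher numbers stand for weaker inhibition and lower numbers for stronger inhibition), compound 1 gives 200 nM and compound 2 gives 37900 nM. Among the measured compounds shown here, compound 2 thus has the highest number of the two, and the one measured step, a 190-fold higher number from compound 1 to compound 2 (2.28 log units; beyond the scatter), shows that replacing pent-1-yn-1-yl with 4-chlorophenyl on the shared core greatly weakened inhibition.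

Compound 3, `Nc1ncnn2c([C@@H]3O[C@H](CO)[C@@H](O)[C@H]3O)cc(-c3ccoc3)c12`, has not been measured. It differs from compound 2 as follows: furan-3-yl in place of 4-chlorophenyl on an aromatic carbon. Both the leaving and the entering groups are aromatic rings, so the step from compound 1 to compound 2 does not bear directly on this change; it only shows that the aromatic carbon in question is sensitive to what sits on it, and that compound 2 is a weak starting point. For the measured compounds named here, with no measured step that tests one aromatic ring against another, the expected change is uncertain; a moderate move toward a lower number seems plausible, though it could also stay within the scatter. Compound 3 is therefore expected to give about 15000 nM, between 3000 nM and 60000 nM, a step estimated as a 2.5-fold lower number from compound 2 to compound 3 (0.40 log units; beyond the scatter).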

Compound 3, half-maximal inhibitory concentration: 500 nM
The estimate for compound 3 lay 30-fold (1.48 log units) above the measured number; the whole stated range lies above it.
By their numbers in this assay, from the lowest: compound 1; then compound 3; then compound 2.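

In this assay, this aromatic carbon proves to distinguish one aromatic ring from another: furan-3-yl in place of 4-chlorophenyl gives (a 76-fold lower number from compound 2 to compound 3 (1.88 log units; beyond the scatter)), a large change between two groups that each carry a single aromatic ring. The poor result for compound 2 therefore cannot be read as a penalty on every aromatic ring at this place, and a ring can come close to the open-chain pent-1-yn-1-yl group, although a modest gap remains (a 2.5-fold higher number from compound 1 to compound 3 (0.40 log units; beyond the scatter)), with compound 1 still giving the lowest number of the three. No measurement available here explains why the two rings behave so differently.

The change from compound 2 to compound 3 alters ring size, ring atoms and the chlorine all at once, so the compounds shown leave open which of these differences matters. A plain phenyl ring or a thiophen-3-yl ring on the same carbon would help to separate these differences, while a longer alkyne chain such as hex-1-yn-1-yl would test how much the chain of compound 1 can be extended.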